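Compound 1 to compound 4: methyl for trifluoromethyl

A few compounds are considered here, and "the series" means these few. Any claim that something is new, unique, unknown or untested is made for them only; others in the source may bear on it.

In an ADME assay on MDBK cells (Bos taurus) for cytotoxicity, read by MTT assay, with a stated time of 72 h (on this read-out higher numbers stand for lower toxicity in this test and lower numbers for higher toxicity in this test), compound 1 `FC(F)(F)c1ccc(NCc2cn(-c3ccccc3)nc2-c2ccc(Br)cc2)cc1` gives 46000 nM, compound 2 `FC(F)(F)c1ccc(NCc2cn(-c3ccccc3)nc2-c2ccc(C(F)(F)F)cc2)cc1` gives 26000 nM and compound 3 `FC(F)(F)c1ccc(NCc2cn(-c3ccccc3)nc2-c2ccc(Cl)cc2)cc1` gives 31000 nM. Compound 1 is not separated from either of the other two: the steps are a 1.8-fold lower number from compound 1 to compound 2 (0.25 log units; within the scatter) and a 1.5-fold lower number from compound 1 to compound 3 (0.17 log units; within the scatter). The remaining step, a 1.2-fold higher number from compound 2 to compound 3 (0.08 log units; within the scatter), is equally small. All three exchange the group that is bromo in compound 1, not the trifluoromethyl that changes next.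

Compound 4 `Cc1ccc(NCc2cn(-c3ccccc3)nc2-c2ccc(Br)cc2)cc1` keeps the bromo and differs from compound 1 by methyl in place of trifluoromethyl on an aromatic carbon, para to a large group. Among the measured compounds shown here, no measured step tests this exchange directly, so the evidence is indirect. The closest guide is compound 2, where a 1.8-fold lower number from compound 1 to compound 2 (0.25 log units; within the scatter) shows a trifluoromethyl exchange at the other site staying within the scatter. No shift beyond the scatter is therefore expected in this assay. The expected step is a 1.1-fold lower number from compound 1 to compound 4 (0.04 log units; within the scatter). For compound 4 the estimated value is 42000 nM, with an expected range of 19000 nM to 90000 nM.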

Compound 4, half-maximal cytotoxic concentration: > 100000 nM
Compound 4: no number, only a limit; the forecaster's own chance of this, stated with the estimate: 15%; middle value at least 2.3-fold (0.37 log units) away from the limit.
By their numbers in this assay, from the lowest: compounds 2, 3 and 1 (each within the scatter of the next). At a limit, above all of these: compound 4.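

In this assay, the change from 4-(trifluoromethyl)phenyl to 4-methylphenyl gives an at least 2.1-fold higher number from compound 1 to compound 4 (0.33 log units; beyond the scatter), whereas the exchanges among bromo, chloro and trifluoromethyl at the other site in compounds 1, 2 and 3 all stay within the scatter. Among the compounds shown, this position is therefore the only one where a single exchange separates two compounds, and the direction is towards lower toxicity in this test. The entry for compound 4 is a limit and not a number, so the step gives only a minimum size: the limit of > 100000 nM in this assay, at which 1 of the 4 values shown sits.

Open, from the compounds shown here alone, is how far the number rises, and whether a methoxy group or an amine at this position would read like methyl or like trifluoromethyl. Also open, going by these compounds, is whether the same exchange gives a similar step when chloro replaces the bromo of compound 4.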